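One Chlorine on the Sulfonyl Aryl Ring

The source may report more compounds than this note shows. Statements on the series, on what has been measured and on what is new or still open speak of the compounds shown alone.

Measured compounds:
Compound 1, `CC1CCN(c2c(S(=O)(=O)c3cc(Cl)cc(Cl)c3)cnc3ccc(Cl)cc23)CC1`: 88%
Compound 2, `CC1CCN(c2c(S(=O)(=O)c3ccccc3)cnc3ccc(Cl)cc23)CC1`: 59%
Compound 3, `CC1CCN(c2c(S(=O)(=O)c3ccc(F)c(F)c3)cnc3ccc(Cl)cc23)CC1`: 72%

The read-out throughout is an assay on isolated protein for displacement of a labelled ligand from metabotropic glutamate receptor 5 (Homo sapiens), with a stated time of 60 min, tested at 1 uM; a higher number here means more inhibition at the concentration tested (going by the name of the read-out), a lower number less inhibition. Compound 3 stands second highest of the three numbers: its nearest neighbour is compound 2 and its furthest is compound 1, with both gaps beyond the scatter.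

Compound 4 is `CC1CCN(c2c(S(=O)(=O)c3ccc(Cl)cc3)cnc3ccc(Cl)cc23)CC1`. It differs from compound 3 in one place:
4-chlorophenyl in place of 3,4-difluorophenyl on a sulfonyl sulfur

For the measured compounds named here, three measured steps bear on this exchange of the ring on the sulfonyl sulfur. Removing both chlorines gave a number 29 percentage points lower from compound 1 to compound 2 (beyond the scatter), and going to two fluorines gave a number 16 percentage points lower from compound 1 to compound 3 (beyond the scatter); from bare phenyl to two fluorines gave a number 13 percentage points higher from compound 2 to compound 3 (beyond the scatter). Compound 4 keeps a single chlorine, so in this assay it is expected to sit between compound 2 and compound 1, close to compound 3, with a step of a number 1 percentage points higher from compound 3 to compound 4 (within the scatter) that is expected to stay within the scatter. The estimate for compound 4 is 73%, ranging from 58% to 86%.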

Compound 4, a percentage reported as inhibition, at one concentration (the size of the read-out at that concentration, not a potency): 92%
Compound 4: middle estimate off by 19 percentage points, on the low side; measured number outside the range, above it.
By their numbers in this assay, from the lowest: compound 2; then compound 3; then compounds 1 and 4 (each within the scatter of the next).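

In this assay, one chlorine on the phenyl ring on the sulfonyl sulfur is enough for the high number: chloro in place of hydrogen gives a number 33 percentage points higher from compound 2 to compound 4 (beyond the scatter), and 4-chlorophenyl in place of 3,4-difluorophenyl gives a number 20 percentage points higher from compound 3 to compound 4 (beyond the scatter), so compound 4, with one halogen, goes against any reading of the earlier numbers as a simple count of halogens on this ring. A second chlorine is not needed either, as 4-chlorophenyl in place of 3,5-dichlorophenyl gives a number 4 percentage points higher from compound 1 to compound 4 (within the scatter). Nothing available explains why chlorine and the two fluorines part so far at this position.

The compounds shown leave open whether this gain is particular to chlorine or would also appear with bromine, methyl, methoxy or trifluoromethyl in its place. They also leave open how a lone fluorine on this ring would compare.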